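Variation at the carbamate oxygen in a weakly inhibiting set

The source may report more compounds than this note shows. Statements on the series, on what has been measured and on what is new or still open speak of the compounds shown alone.

Compound 3 `C[C@@H]1CN(C(=O)c2nc(Nc3cc(C4CC4)[nH]n3)c3cc(Cl)ccc3n2)CCN1C(=O)OCOC(=O)C(C)(C)C` is one of three analogues of a shared core that differ only in the group on an oxygen next to a carbonyl group. In an assay for inhibition of serine/threonine-protein kinase PAK 4 (Homo sapiens), read by FRET and Z'-LYTE, with a stated time of 60 min, tested at 0.5 uM, in the presence of a further agent that is not named here (on this read-out higher numbers stand for a stronger effect at the one concentration tested and lower numbers for a weaker effect), compound 3 gives 0.7%, the second highest of the three numbers; compound 2 `C[C@@H]1CN(C(=O)c2nc(Nc3cc(C4CC4)[nH]n3)c3cc(Cl)ccc3n2)CCN1C(=O)OCC(Cl)(Cl)Cl` gives -1.5% and compound 1 `CC(OC(=O)C(C)C)OC(=O)N1CCN(C(=O)c2nc(Nc3cc(C4CC4)[nH]n3)c3cc(Cl)ccc3n2)C[C@H]1C` gives 9.4%. The steps among them are small: a number 10.9 percentage points lower from compound 1 to compound 2 (beyond the scatter), a number 8.7 percentage points lower from compound 1 to compound 3 (within the scatter), and a number 2.2 percentage points higher from compound 2 to compound 3 (within the scatter).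

Compound 4 `CCOC(=O)N1CCN(C(=O)c2nc(Nc3cc(C4CC4)[nH]n3)c3cc(Cl)ccc3n2)C[C@H]1C` has not yet been measured. It differs from compound 3 in one place: methyl in place of ((tert-butyl)carbonyl)oxy on a saturated chain carbon bound to an oxygen next to a carbonyl group. Going by the values given here, the step from compound 2 to compound 3 changed the group at the same place and stayed within the scatter, and the only step beyond the scatter, from compound 1 to compound 2, was modest. The expected step of a number 1.3 percentage points higher from compound 3 to compound 4 (within the scatter) is therefore none beyond the scatter. Compound 4 is estimated at 2%, with a range from -8% to 12%.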

Compound 4, a percentage reported as inhibition, at one concentration (the size of the read-out at that concentration, not a potency): 42.4%
Compound 4: the middle estimate sits 40.4 percentage points below what was measured; the measured number lies above the stated range.
By their numbers in this assay, from the lowest: compounds 2, 3 and 1 (each within the scatter of the next, the first and the last beyond it); then compound 4.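

The this assay read-out does respond to the group at this place, which the three earlier compounds, lying close together, had not shown: with ethyl in the ethoxycarbonyl group of compound 4, the result is a number 41.7 percentage points higher from compound 3 to compound 4 (beyond the scatter) and a number 43.9 percentage points higher from compound 2 to compound 4 (beyond the scatter) and also a number 33 percentage points higher from compound 1 to compound 4 (beyond the scatter) in one consistent direction. All three earlier groups are larger than ethyl and carry a substituent on the saturated chain carbon bound to an oxygen next to a carbonyl group, and the plain methyl on that carbon is what sets compound 4 apart. No evidence is available here to explain this rise.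

Going by these compounds, whether a propyl chain, a methoxy-bearing ethyl or a bare methyl carbamate would keep or lose this effect remains open. The read-out at one concentration also gives no potency for compound 4.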